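The compounds below may be only part of what the source reports. "The series", "measured", "known", "first", "only" and "open" are said of these compounds alone.

Compound 1 `Fc1cccc(Cn2ccc3nc(-c4ccccc4)nc-3c2)c1` and compound 2 `Clc1cccc(Cn2ccc3nc(-c4ccccc4)nc-3c2)c1` share one core and differ in a single group on an aromatic carbon. In an ADME assay on MDBK cells (Bos taurus) for cytotoxicity (a lower number here means that less compound is tolerated, a higher number that more compound is tolerated), compound 1 gives > 100000 nM, which is a limit of the assay and not a number. In this assay compound 2 stands at > 100000 nM, which is again a limit and not a number. The picture so far is the limit of > 100000 nM in this assay, at which 2 of the 2 values shown sit. The next compound, compound 3 `FC(F)(F)c1cccc(Cn2ccc3nc(-c4ccccc4)nc-3c2)c1`, carries trifluoromethyl in place of chloro on an aromatic carbon, meta to a large group: trifluoromethyl in place of chloro on an aromatic carbon. Among the measured compounds shown here, the one measured step that bears on this change is a step that the two limits leave unreadable from compound 1 to compound 2, so it offers no size to carry forward. With both measured neighbours sitting at the limit, no shift in either direction beyond the scatter is expected in this assay, and the estimated step is a number no higher from compound 2 to compound 3 (the limit leaves the size open). A further report of a limit is the most likely outcome. As a number, compound 3 is expected at 100000 nM, with an estimated range from 40000 nM to 200000 nM.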

Compound 3, half-maximal cytotoxic concentration: 98000 nM
Estimate against measurement, compound 3: 1.0-fold (0.01 log units) above; low and high end bracket the measured number.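

Compound 3 is the only one of the three compounds shown that gives a number rather than a limit in this assay, so this position on the aromatic ring now has one readable value to hold against the two limits. With trifluoromethyl in the place of chloro, the result is an at least 1.0-fold lower number from compound 2 to compound 3 (0.00 log units; that floor lies within the scatter), and with trifluoromethyl in the place of fluoro, it is an at least 1.0-fold lower number from compound 1 to compound 3 (0.00 log units; that floor lies within the scatter); neither step therefore establishes a real change, even though the entering group has more heavy atoms than either group it replaces. Across fluoro, chloro and trifluoromethyl at this position, the tolerated concentration in this assay thus remains at or close to the limit of the assay: the limit of > 100000 nM in this assay, at which 2 of the 3 values shown sit.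

The compounds shown leave open whether any group at this position can move the read-out beyond the scatter, as all three carry only fluoro, chloro or trifluoromethyl there. As far as these compounds go, an amine, a carboxylic acid or a longer chain on the same aromatic carbon might still do so, and the effect of such groups in this assay remains unknown.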